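The source may report more compounds than this note shows. Statements on the series, on what has been measured and on what is new or still open speak of the compounds shown alone.

Compound 1 `O=C(NNC(=O)C1CC1c1ccc(OCC(F)(F)F)cc1)c1ccncc1` in a functional assay on OE21 cells (Homo sapiens) for inhibition, read by MTT assay, with a stated time of 72 h (on this read-out higher numbers stand for weaker inhibition and lower numbers for stronger inhibition), gives 31000 nM. Compound 2 `COc1ccc(C2CC2C(=O)NNc2nncc3ccccc23)cc1` in this assay gives 48000 nM. Compound 3 `CC(C)=CCOc1ccc(C2CC2C(=O)NNC(=O)c2ccncc2)cc1` in this assay gives "not determined" (no result reported).

In this assay compound 2 gives 48000 nM, the higher of the two numbers recorded. The nearest is compound 1, which in this assay gives 31000 nM; the gap between the two lies within the scatter of this kind of measurement, so no order between them can be read. Compound 3 in this assay gives "not determined" (no result reported), so it offers no number.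

Compound 4 `O=C(NNc1nncc2ccccc12)C1CC1c1ccc(OC(F)(F)F)cc1` differs from compound 2 in a single place: trifluoromethyl in place of methyl on an oxygen on an aromatic ring. The two compounds share the same core, so the comparison isolates that one change. Among the measured compounds shown here, no measured pair in this set shows this change, and the only other compound with a fluorinated side chain on the aromatic oxygen, compound 1, has a different core, so it cannot serve as a guide.

With nothing to point in either direction, the step from compound 2 to compound 4 is expected to stay within the scatter, at a 1.2-fold lower number from compound 2 to compound 4 (0.08 log units; within the scatter). Compound 4 is accordingly estimated at 40000 nM, with a range from 15000 nM to 110000 nM.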

Compound 4, half-maximal inhibitory concentration: 42000 nM
Compound 4: the middle estimate sits 1.1-fold (0.02 log units) below what was measured; the range from low to high includes it.
By their numbers in this assay, from the lowest: compounds 1, 4 and 2 (each within the scatter of the next).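

In this assay, replacing methyl with trifluoromethyl on the oxygen on the aromatic ring gives a 1.1-fold lower number from compound 2 to compound 4 (0.06 log units; within the scatter). Among the compounds shown here, this is the first measured pair in the set to show this change, and on the shared core the read-out does not separate methoxy from trifluoromethoxy, even though the entering group brings three more heavy atoms. Nothing measured here accounts for this result.

On these data alone, it remains open whether the same change would read alike on the core of compound 1, which differs from compound 4 in more than one place. As far as these compounds go, it is also open whether a chain ending in an amine or a carboxylic acid on this oxygen would move the number beyond the scatter.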